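Swapping the amide aryl cap for a saturated ring

The compounds below may be only part of what the source reports. "The series", "measured", "known", "first", "only" and "open" are said of these compounds alone.

Measured so far:
Compound 1 `CC[C@@H](NC(=O)c1ccccc1)C(=O)N1CCC(c2ccc(Cl)cc2)CC1`: 121 nM
Compound 2 `CC(C)[C@@H](NC(=O)c1cccc(F)c1)C(=O)N1CCC(c2ccc(Cl)cc2)CC1`: 24 nM
Compound 3 `CC(C)C(NC(=O)c1ccc2ccccc2c1)C(=O)N1CCC(c2ccc(Cl)cc2)CC1`: 80 nM

In an assay on THP-1 cells for displacement of a labelled ligand from C-C chemokine receptor type 1 (Homo sapiens) (a higher number here means a weaker inhibitor, a lower number a stronger inhibitor), compound 2 gives the lowest number of the three, and its gaps to compound 3 and to compound 1 both lie beyond the scatter, so it is the strongest inhibitor in this set. Compound 4 `CC(C)[C@@H](NC(=O)C1CCCC1)C(=O)N1CCC(c2ccc(Cl)cc2)CC1` keeps the core of compound 2 and alters only the cap on the amide: cyclopentyl in place of 3-fluorophenyl on a carbonyl carbon. Among the measured compounds shown here, no measured pair shows this kind of change, so the direction rests on expectation alone. A weakening step in this assay that goes beyond the scatter is expected, since compounds 1 to 3 show that the cap matters. For compound 4 the estimate is 100 nM, in the range 30 nM to 400 nM, which is an expected step of a 4.2-fold higher number from compound 2 to compound 4 (0.62 log units; beyond the scatter).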

Compound 4, half-maximal inhibitory concentration: 70 nM
The estimate for compound 4 lay 1.4-fold (0.15 log units) above the measured number, and the stated range covers the measured number.
By their numbers in this assay, from the lowest: compound 2; then compounds 4, 3 and 1 (each within the scatter of the next).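

Replacing 3-fluorophenyl with cyclopentyl on the carbonyl carbon gives a 2.9-fold higher number from compound 2 to compound 4 (0.46 log units; beyond the scatter) in this assay, the first change measured at this place with the rest of the molecule held constant. An aromatic cap is therefore not required for inhibition in the nanomolar range, although compound 2 remains the stronger inhibitor of this pair. Nothing shown explains this step. Still open, on these data alone, is how an open chain such as tert-butyl, or a cap carrying an amine or a carboxylic acid, would compare at this place.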